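Sulfonamide series: an aryl swap toward compound 3

The source may hold more compounds than are shown below. What is called first, only, known or untested is meant among the compounds shown, and "the series" means these compounds.

Measured so far:
compound 1, `Cc1ccc(S(=O)(=O)Nc2ccc(S(N)(=O)=O)cc2)cc1` — 222000 nM
compound 2, `CCOc1ccc(NS(=O)(=O)c2ccc(F)cc2)cc1` — "not determined" (no result reported)

The only figure in hand comes from an assay on isolated protein for inhibition of alkaline phosphatase, tissue-nonspecific isozyme (Bos taurus), read by chemiluminescence and spectrophotometry (a higher number here means a weaker inhibitor, a lower number a stronger inhibitor), where compound 1 gives 222000 nM, a weak result. Compound 2, `CCOc1ccc(NS(=O)(=O)c2ccc(F)cc2)cc1`, is recorded in this assay as "not determined" (no result reported), so its standing cannot be placed on the scale; nothing ties it to compound 1 beyond the shared sulfonamide link.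

Compound 3, `CCOc1ccc(NS(=O)(=O)c2ccc(C)cc2)cc1`, is not yet measured. The change from compound 2 is methyl in place of fluoro on an aromatic carbon, with no change in donor or acceptor count and no change in charge. Going by the values given here, no step between measured compounds exists to set the size of such a swap, and compound 2 itself carries no number, so no direction beyond the scatter can be asserted.

Taking the weak value of compound 1 as the only anchor, compound 3 is expected to give about 200000 nM in this assay, with a likely range of 50000 nM to 900000 nM.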

Compound 3, half-maximal inhibitory concentration: 310 nM
For compound 3 the middle estimate is 650-fold (2.81 log units) above the measured one, outside the stated range (below it).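

In this assay the series now has its first sized change: ethoxy in place of sulfamoyl on an aromatic carbon gives a 720-fold lower number from compound 1 to compound 3 (2.85 log units; beyond the scatter), with the methyl side held constant, so the activity depends strongly on which of these two groups is present. The methyl in place of fluoro step cannot be read, as compound 2 has no number, and the contribution of the group para to a large group remains unsized. No measurement at hand accounts for the size of the ethoxy step.

Still open, as far as these compounds go, is whether a longer chain or an amine at the ethoxy place would keep this level of inhibition. Equally open, from the compounds shown here alone, is how a chloro or a carboxylic acid would compare with methyl on the other aromatic carbon.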